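Furan-3-yl Replaces Thiophen-2-yl on a Shared Nucleoside Core

The compounds below may be only part of what the source reports. "The series", "measured", "known", "first", "only" and "open" are said of these compounds alone.

Measured compounds:
- Compound 1, `O=c1[nH]cnc2c1c(-c1cc3ccccc3o1)cn2[C@@H]1O[C@H](CO)[C@@H](O)[C@H]1O`, gives > 20000 nM in a functional assay on HeLa S3 cells (Homo sapiens) for antiproliferative activity, read by XTT assay, with a stated time of 72 h; on this read-out higher numbers stand for weaker inhibition and lower numbers for stronger inhibition.
- Compound 2, `O=c1[nH]cnc2c1c(-c1cccs1)cn2[C@@H]1O[C@H](CO)[C@@H](O)[C@H]1O`, gives > 20000 nM in this assay.
- Compound 3, `Cc1nc(N)c2c(-c3ccsc3)cn([C@@H]3O[C@H](CO)[C@@H](O)[C@H]3O)c2n1`, gives > 20000 nM in this assay.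

The value of compound 1 is a limit of the assay, not a number. The value of compound 2 is likewise a limit. The value of compound 3 is also a limit. Compound 2 therefore stands nowhere in particular on the numbers shown: every value sits at the same boundary, (the limit of > 20000 nM in this assay, at which 3 of the 3 values shown sit), and none of the three can be ordered against another.

Among the compounds with values here, the only pair differing in one place is the one giving a step that the two limits leave unreadable from compound 1 to compound 2, a step that cannot be read because both ends are limits.

Compound 4, `O=c1[nH]cnc2c1c(-c1ccoc1)cn2[C@@H]1O[C@H](CO)[C@@H](O)[C@H]1O`, is not yet measured. It differs from compound 2 as furan-3-yl in place of thiophen-2-yl on an aromatic carbon. No readable step bears on this change, and the three measured compounds offer nothing but the boundary itself. The expected step in this assay is therefore none beyond the scatter, most likely ending again at a limit. Compound 4 is estimated at 30000 nM, with a range from 8000 nM to 120000 nM. That estimate means an expected step that the limit leaves unreadable from compound 2 to compound 4.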

Compound 4, half-maximal inhibitory concentration: > 20000 nM
Compound 4: no number, only a limit (the forecaster's own chance of this, stated with the estimate: 85%); the middle value is on the limit's open side.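

Compound 4 gives only a limit in this assay, as do compound 1 and compound 2, so the steps from compound 2 to compound 4 and from compound 1 to compound 4 cannot be read. All the results share one boundary: the limit of > 20000 nM in this assay, at which 4 of the 4 values shown sit.

As far as these compounds go, whether furan-3-yl and thiophen-2-yl differ at all in this assay remains open.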